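Trimming the Amide Aryl Group of Compound 3

The compounds below may be only part of what the source reports. "The series", "measured", "known", "first", "only" and "open" are said of these compounds alone.

Compound 3 `COc1cc(-c2nn(-c3cccc(NC(=O)c4ccc(Cl)c(C(F)(F)F)c4)c3)cc2-c2ccncc2)ccc1Cl` gives 2420 nM in a functional assay on OVCAR-3 cells (Homo sapiens) for inhibition, read by sulforhodamine B assay, with a stated time of 48 h (a lower number here means a stronger inhibitor, a higher number a weaker inhibitor), the highest number among the three measured compounds. Compound 1 `O=C(Nc1cccc(-n2cc(-c3ccncc3)c(-c3ccc(Cl)c(O)c3)n2)c1)Nc1cccc(C(F)(F)F)c1` gives 1060 nM in this assay, and compound 2 `COc1cc(-c2nn(-c3cccc(NC(=O)Nc4cccc(C(F)(F)F)c4)c3)cc2-c2ccncc2)ccc1Cl` gives 580 nM in this assay; the step of a 1.8-fold lower number from compound 1 to compound 2 (0.26 log units; within the scatter) lies within the scatter, whereas a 4.2-fold higher number from compound 2 to compound 3 (0.62 log units; beyond the scatter) lies beyond it. Compound 4 `COc1cc(-c2nn(-c3cccc(NC(=O)c4ccccc4)c3)cc2-c2ccncc2)ccc1Cl` differs from compound 3 by phenyl in place of 4-chloro-3-(trifluoromethyl)phenyl on a carbonyl carbon. Within the data shown here, no measured step alters the substituents on the aryl group of the amide, so the expectation rests only on a 4.2-fold higher number from compound 2 to compound 3 (0.62 log units; beyond the scatter), which touched the same carbonyl carbon and was modest. Compound 4 is therefore expected to show a small step in this assay, upward or none beyond the scatter, a 1.4-fold higher number from compound 3 to compound 4 (0.16 log units; within the scatter). Compound 4 is estimated at 3500 nM, within 1200 nM to 10000 nM.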

Compound 4, half-maximal inhibitory concentration: 330 nM
Compound 4: middle estimate off by 11-fold (1.03 log units), on the high side; the whole stated range lies above it.
By their numbers in this assay, from the lowest: compounds 4, 2 and 1 (each within the scatter of the next, the first and the last beyond it); then compound 3.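

Losing the chlorine and the trifluoromethyl together from the aryl group on the carbonyl carbon gives a 7.3-fold lower number from compound 3 to compound 4 (0.87 log units; beyond the scatter) in this assay and shows that this position responds strongly to its substituents. Phenyl in place of (3-(trifluoromethyl)phenyl)amino gives a 1.8-fold lower number from compound 2 to compound 4 (0.24 log units; within the scatter) and leaves those two compounds unseparated, so the high number of compound 3 goes with its substituents, not with the amide as such. No evidence at hand explains these steps.

The compounds shown leave open which of the chlorine and the trifluoromethyl carries the step, since both leave together. Also open, on these data alone, is how a phenyl bearing an amine or a carboxylic acid, or a longer chain on the carbonyl carbon, would read.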